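The source may report more compounds than this note shows. Statements on the series, on what has been measured and on what is new or still open speak of the compounds shown alone.

Compound 1 `O=C(O)/C(S)=C/c1ccc(I)cc1` is the simplest member of this set, and in an assay on isolated protein for inhibition of Calpain-1 catalytic subunit (Sus scrofa), read by FRET (a higher number here means a weaker inhibitor, a lower number a stronger inhibitor), compound 1 gives 2200 nM. Compound 2 `O=C(O)/C(S)=C/c1ccc(Br)cc1` differs from it by bromo in place of iodo on an aromatic carbon, and in this assay compound 2 gives 1500 nM; the step is a 1.5-fold lower number from compound 1 to compound 2 (0.17 log units; within the scatter). Compound 3 `O=C(O)/C(S)=C/c1c[nH]c2ccc(I)cc12` carries the same acid-bearing side chain on a different core; the difference between the two cores is not broken down here. In this assay compound 3 gives 100 nM, the lowest number among the three measured compounds, and its steps to compound 2 and to compound 1 both lie beyond the scatter.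

Compound 4 `O=C(O)/C(S)=C/c1c[nH]c2ccc(Br)cc12` is the unmeasured partner of compound 3, made by bromo in place of iodo on an aromatic carbon. Within the data shown here, this is the same kind of change as the one from compound 1 to compound 2, not the same: there the halogen sat para to a group of 6 heavy atoms, whereas here it sits on a ring that is part of a fused or bridged system of two rings, meta to a fused ring and para to a fused ring. Since the earlier exchange gave only a 1.5-fold lower number from compound 1 to compound 2 (0.17 log units; within the scatter), a step of similar size, within the scatter, is expected from compound 3 to compound 4, namely a 1.3-fold lower number from compound 3 to compound 4 (0.10 log units; within the scatter). Compound 4 is therefore estimated at 80 nM, most likely between 35 nM and 200 nM.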

Compound 4, half-maximal inhibitory concentration: 6 nM
For compound 4 the middle estimate is 13-fold (1.12 log units) above the measured one; the whole stated range lies above it.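

In this assay, bromo in place of iodo on an aromatic carbon gives a 17-fold lower number from compound 3 to compound 4 (1.22 log units; beyond the scatter), so on this core the exchange of one halogen for the other is a large step. The same change does not carry over in size from one core to the other: the same change on two cores in this assay, a 1.5-fold lower number (0.17 log units; within the scatter) from compound 1 to compound 2 and a 17-fold lower number (1.22 log units; beyond the scatter) from compound 3 to compound 4, 11-fold (1.06 log units) apart, beyond the scatter of two such steps. Among these compounds, this shows that, across these two pairs, the size of the step depends on the core to which the change is applied, but it does not show which feature of the core is responsible, and with only one pair on each core it gives no way to predict the step on a third core.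

The compounds shown leave open how chloro or fluoro on the same aromatic carbon would compare with bromo and iodo on either core, and so whether the large step is particular to this pair of halogens. They also leave open whether the large step would persist with a methyl ester in place of the carboxylic acid.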